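From benzylcarbamoyl to benzylsulfonyl on a shared core

The source may hold more compounds than are shown below. What is called first, only, known or untested is meant among the compounds shown, and "the series" means these compounds.

Compound 1 `CS(=O)(=O)N[C@@H](CNC(=O)c1ccc2c(c1)C(=O)N(CCC1CCNCC1)C2)C(=O)O`: 14 nM
Compound 2 `CC(C)CS(=O)(=O)N[C@@H](CNC(=O)c1ccc2c(c1)C(=O)N(CCC1CCNCC1)C2)C(=O)O`: 9 nM
Compound 3 `O=C(NCc1ccccc1)N[C@@H](CNC(=O)c1ccc2c(c1)C(=O)N(CCC1CCNCC1)C2)C(=O)O`: 10 nM

In a functional assay for inhibition, with Homo sapiens as the target (on this read-out higher numbers stand for weaker inhibition and lower numbers for stronger inhibition), compound 3 gives 10 nM, within the scatter of the other two numbers, as a 1.4-fold lower number from compound 1 to compound 3 (0.15 log units; within the scatter) and a 1.1-fold higher number from compound 2 to compound 3 (0.05 log units; within the scatter) show. Compound 4 `O=C(NC[C@H](NS(=O)(=O)Cc1ccccc1)C(=O)O)c1ccc2c(c1)C(=O)N(CCC1CCNCC1)C2`, not yet measured, differs from it thus: benzylsulfonyl in place of benzylcarbamoyl on an amine nitrogen. In words, benzylsulfonyl stands in place of benzylcarbamoyl on an amine nitrogen. Those same two steps swap a sulfonyl group and benzylcarbamoyl on that nitrogen, and changing the sulfonyl chain gave a 1.6-fold lower number from compound 1 to compound 2 (0.19 log units; within the scatter). All three stay within the scatter, so no step beyond the scatter is expected in this assay here. The expected change is no change at the digits printed from compound 3 to compound 4 (within the scatter). Compound 4 is estimated at 10 nM, with an expected range from 5 nM to 20 nM.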

Compound 4, half-maximal inhibitory concentration: 4 nM
Beside the measured number, compound 4's estimate is 2.5-fold (0.40 log units) above it, outside the stated range (below it).
By their numbers in this assay, from the lowest: compound 4; then compounds 2, 3 and 1 (each within the scatter of the next).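

In this assay the changes on this amine nitrogen pass the scatter only when they lead to compound 4: benzylsulfonyl in place of benzylcarbamoyl gives a 2.5-fold lower number from compound 3 to compound 4 (0.40 log units; beyond the scatter) on the shared core. On the saturated chain carbon bound to the sulfonyl sulfur, phenyl gives a 2.3-fold lower number from compound 2 to compound 4 (0.35 log units; beyond the scatter) in place of isopropyl and a 3.5-fold lower number from compound 1 to compound 4 (0.54 log units; beyond the scatter) in place of hydrogen. Nothing available here explains these steps. The compounds shown leave open how a 2-phenylethylsulfonyl or pyridylmethylsulfonyl group on this nitrogen would read. They also leave open whether a methyl ester could stand in place of the carboxylic acid.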